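The source may report more compounds than this note shows. Statements on the series, on what has been measured and on what is new or still open speak of the compounds shown alone.

Compound 1 `O=c1c(-c2ccc(O)cc2)coc2cc(OCCCCCCCCCO)ccc12` gives 700 nM in an assay (Cricetulus griseus) for inhibition of aldehyde dehydrogenase, mitochondrial (Homo sapiens) (a higher number here means a weaker inhibitor, a lower number a stronger inhibitor), the lowest of the three numbers available here. Compound 2 `O=C(O)CCCCCOc1ccc2c(=O)cc(-c3ccc(O)cc3)oc2c1` gives 3500 nM in this assay, and compound 3 `CCCCC(Oc1ccc2c(=O)c(-c3ccc(O)cc3)coc2c1)C(=O)OCC` gives 4500 nM in this assay; each of these two values lies beyond the scatter above that of compound 1. Compound 4 `CCCCCCCCCCCCOc1ccc2c(=O)c(-c3ccc(O)cc3)coc2c1` differs from compound 1 in one place: propyl in place of hydroxy on a saturated chain carbon, nine bonds along the chain from an oxygen on an aromatic ring. Going by the values given here, no measured pair shows this change, so its size can only be guessed from the three values at hand. Since the two compounds carrying an acid or ester at the chain end both sit higher than compound 1, a modest step toward a lower number is expected, as a 1.4-fold lower number from compound 1 to compound 4 (0.15 log units; within the scatter). Compound 4 is estimated at 500 nM, within a range from 150 nM to 2000 nM.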

Compound 4, half-maximal inhibitory concentration: > 9000 nM
Compound 4: no number, only a limit (the forecaster's own chance of this, stated with the estimate: 5%); middle value at least 18-fold (1.25 log units) away from the limit.
By their numbers in this assay, from the lowest: compound 1; then compounds 2 and 3 (each within the scatter of the next). At a limit, above all of these: compound 4.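

For compound 4, this assay returns only a limit, not a number: the limit of > 9000 nM in this assay, at which 1 of the 4 values shown sits. Even so, propyl in place of hydroxy on a saturated chain carbon, nine bonds along the chain from an oxygen on an aromatic ring, is a large change, giving an at least 12-fold higher number from compound 1 to compound 4 (1.10 log units; beyond the scatter). The earlier compounds shown here could not isolate this chain end, and here it alone separates the two compounds.

Going by these compounds, how far the true number for compound 4 lies past its limit stays open. So does whether an amine or a methyl ether at the same chain end, or a shorter chain ending in hydroxy, would hold the number of compound 1.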